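Halogen change on the aryl ring: compound 3 to compound 4

The source may report more compounds than this note shows. Statements on the series, on what has been measured and on what is new or still open speak of the compounds shown alone.

Measured so far:
compound 1 `CC(=O)N1N=C(c2ccc(C)cc2)CC1c1cn(-c2ccccc2)nc1-c1ccc(Cl)c(Cl)c1`: 27.7%
compound 2 `O=CN1N=C(c2ccc(Cl)cc2)CC1c1cn(-c2ccccc2)nc1-c1ccc(Cl)c(Cl)c1`: 35.1%
compound 3 `CC(=O)N1N=C(c2ccc(F)cc2)CC1c1cn(-c2ccccc2)nc1-c1ccc(Cl)c(Cl)c1`: 45.7%

In a functional assay on the whole organism (strain Wistar) for inhibition, with Rattus norvegicus as the target, read by paw edema, with a stated time of 30 min, at a dose of 50 mg/kg by the oral route (on this read-out lower numbers stand for less inhibition and higher numbers for more inhibition at the one dose given (going by the name of the read-out)), compound 3 stands highest of the three, with compound 2 nearest and compound 1 furthest, both gaps beyond the scatter. Going by the values given here, the one single-place step in the set is a number 18 percentage points higher from compound 1 to compound 3 (beyond the scatter), a modest gain with fluoro in place of methyl.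

Compound 4 `CC(=O)N1N=C(c2ccc(Cl)cc2)CC1c1cn(-c2ccccc2)nc1-c1ccc(Cl)c(Cl)c1` differs from compound 3 by chloro in place of fluoro on an aromatic carbon. Among the compounds with values here, no measured step covers chloro in place of fluoro directly. Compound 2 carries chloro on that ring but also differs in the group on the ring nitrogen, so its value only shows that a chloro analogue can sit somewhat below compound 3. The expected change is therefore small, a number 5.7 percentage points lower from compound 3 to compound 4 (within the scatter), with no direction firmly indicated. For compound 4 the estimated value is 40%, with a range from 28% to 52%.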

Compound 4, a percentage reported as inhibition, in the whole organism at one dose (the size of the read-out at that dose, not a potency): 45.7%
Compound 4: the middle estimate sits 5.7 percentage points below what was measured; the measured number falls inside the stated range.
By their numbers in this assay, from the lowest: compounds 1 and 2 (each within the scatter of the next); then compounds 3 and 4 (each within the scatter of the next).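

In this assay the change from 4-fluorophenyl to 4-chlorophenyl gives no change at the digits printed from compound 3 to compound 4 (within the scatter), so on this aromatic carbon, para to a large group, the two halogens are not told apart. Chloro in place of methyl gives a number 18 percentage points higher from compound 1 to compound 4 (beyond the scatter), the same size as the fluoro step from that compound, and methyl in place of hydrogen on the carbonyl carbon gives a number 10.6 percentage points higher from compound 2 to compound 4 (beyond the scatter) with chloro held on the ring. No measured evidence on the cause of these steps is available.

Open, going by these compounds, is whether an amine or a carboxylic acid at this ring position holds the number, and whether a longer chain in place of the methyl on the carbonyl carbon does.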